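One More Carbon on the Chain: Compound 3 to Compound 4

The source may report more compounds than this note shows. Statements on the series, on what has been measured and on what is new or still open speak of the compounds shown alone.

Three compounds sharing one core differ only in the length of a saturated chain attached to a sulfur. Compound 1 `CCCCCCCSC[C@H](NC(C)=O)C(=O)CCl` gives 4800 nM in a functional assay on NALM-6 cells (Homo sapiens); a higher number here means a weaker inhibitor, a lower number a stronger inhibitor. Compound 2 `CCCCCCCCCCCSC[C@H](NC(C)=O)C(=O)CCl` gives 1700 nM in this assay, and compound 3 `CCCCCCCCCCCCCCSC[C@H](NC(C)=O)C(=O)CCl` gives 8700 nM in this assay, the highest of the three numbers, although its gap to compound 1 lies within the scatter. Compound 4 `CCCCCCCCCCCCCCCSC[C@H](NC(C)=O)C(=O)CCl` has not yet been measured. The change from compound 3 is methyl in place of hydrogen on a saturated chain carbon, ten or more bonds along the chain from a sulfur. Of the measured steps, a 2.8-fold lower number from compound 1 to compound 2 (0.45 log units; beyond the scatter), whereas a 5.1-fold higher number from compound 2 to compound 3 (0.71 log units; beyond the scatter); in addition, a 1.8-fold higher number from compound 1 to compound 3 (0.26 log units; within the scatter). Lengthening the chain first lowered and then raised the number, so no single direction holds across these compounds, and the present change adds only a single carbon. For compound 4 the step of a 1.1-fold higher number from compound 3 to compound 4 (0.06 log units; within the scatter) is therefore expected to be small, at most a modest rise. Compound 4 is estimated at 10000 nM, with a range from 4000 nM to 25000 nM.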

Compound 4, half-maximal inhibitory concentration: 8900 nM
Compound 4: the middle estimate sits 1.1-fold (0.05 log units) above what was measured; measured number inside the range.
By their numbers in this assay, from the lowest: compound 2; then compounds 1, 3 and 4 (each within the scatter of the next).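

In this assay, methyl in place of hydrogen on a saturated chain carbon, ten or more bonds along the chain from a sulfur, gives a 1.0-fold higher number from compound 3 to compound 4 (0.01 log units; within the scatter), so at this chain length one more carbon makes no readable difference. The chain of compound 4 still stands clearly apart from the one shorter chain that did best, with a 5.2-fold higher number from compound 2 to compound 4 (0.72 log units; beyond the scatter), yet a 1.9-fold higher number from compound 1 to compound 4 (0.27 log units; within the scatter) is a step too small to read, even though it spans octyl. Compound 2 therefore remains the strongest inhibitor of the four, and nothing shown explains why the numbers run this way. The compounds shown leave open where, between compound 2 and compound 3, the number starts to rise. They also leave open how a chain carrying an amine or a carboxylic acid would behave.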